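Swapping the thiophene attachment point in a thromboxane synthase series

The source may hold more compounds than are shown below. What is called first, only, known or untested is meant among the compounds shown, and "the series" means these compounds.

Compound 3 `O=C(O)CCCC/C=C(\c1cccnc1)c1ccsc1` gives 31 nM in an assay (Equus caballus) for inhibition of Thromboxane-A synthase (Homo sapiens), using microsomes; a lower number here means a stronger inhibitor, a higher number a weaker inhibitor.
Compound 2 `O=C(O)C(CCC/C=C(\c1cccnc1)c1cccs1)c1ccccc1` gives 50 nM in this assay.
Compound 1 `O=C(O)CCCC/C=C(/c1ccc(Br)cc1)c1cccnc1` gives 82 nM in this assay.

Compound 3 gives the lowest of the three numbers, but its gap to compound 2 lies within the scatter, and only compound 1 stands clearly apart from it. Going by the values given here, the one measured step that reaches compound 3 is a 2.6-fold lower number from compound 1 to compound 3 (0.42 log units; beyond the scatter), which shows that exchanging the aryl group on that chain carbon can move the number, though not greatly.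

Compound 4 `O=C(O)CCCC/C=C(\c1cccnc1)c1cccs1` is the next member to be measured. It keeps every atom of compound 3 and changes only the point at which the thiophene is joined: thiophen-2-yl in place of thiophen-3-yl on a double-bonded chain carbon bound to an aromatic carbon and a double-bonded chain carbon.

Among the compounds with values here, no measured step isolates this kind of change. Compound 2 carries thiophen-2-yl and compound 3 carries thiophen-3-yl, yet the two also differ elsewhere on the chain, and their values lie within the scatter of one another, so they offer no direction. He therefore expects compound 4 to stay close to compound 3, with a step of a 1.3-fold higher number from compound 3 to compound 4 (0.11 log units; within the scatter) no larger than the scatter. His estimate for compound 4 is 40 nM, within a range from 15 nM to 110 nM.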

Compound 4, half-maximal inhibitory concentration: 20 nM
Estimate against measurement, compound 4: 2.0-fold (0.30 log units) above, within the range that was stated.
By their numbers in this assay, from the lowest: compounds 4, 3, 2 and 1 (each within the scatter of the next, the first and the last beyond it).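

Changing only the attachment point of the thiophene gives a 1.6-fold lower number from compound 3 to compound 4 (0.19 log units; within the scatter) in this assay, so this position tolerates the swap from thiophen-3-yl to thiophen-2-yl without the two compounds being separable. The thiophen-2-yl compound also stands clear of the 4-bromophenyl compound, with a 4.1-fold lower number from compound 1 to compound 4 (0.61 log units; beyond the scatter) at the same double-bonded chain carbon, while a second position gets its first reading in a 2.5-fold lower number from compound 2 to compound 4 (0.40 log units; beyond the scatter), where hydrogen replaces phenyl on a saturated chain carbon bound to a carbonyl carbon and a saturated chain carbon. Nothing available explains why any of these numbers differ.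

Whether phenyl on that saturated chain carbon would give a similar step alongside thiophen-3-yl stays open, since the pair shown has it only with thiophen-2-yl. The compounds shown also leave open how a furan-2-yl group or an unsubstituted phenyl would read on the double-bonded chain carbon, and whether a longer chain carrying the carboxylic acid would hold the numbers seen for compound 3 and compound 4.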